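Exposure After Replacing Cyclopropyl with 4-Fluorophenyl

The source may report more compounds than this note shows. Statements on the series, on what has been measured and on what is new or still open speak of the compounds shown alone.

In an ADME assay on the whole organism (Mus musculus, strain BALB/C) for pharmacokinetics, read by LC-MS, with a stated time of 24 h, at a dose of 10 mg/kg by the oral route (a higher number here means more compound in the circulation at the dose given, a lower number less compound in the circulation), two compounds have been measured:
compound 1 `Cc1c([C@H](C)Nc2nc(N)nc(N)c2C#N)c(-c2ccccc2)c(=O)n2cc(F)ccc12` with 2100 nM
compound 2 `C[C@H](Nc1nc(N)nc(N)c1C#N)c1c(-c2ccccc2)c(=O)n2cc(F)ccc2c1C1CC1` with 1300 nM

For the measured compounds named here, compound 2 holds the lower of the two numbers, with compound 1 nearest; the only measured step, a 1.6-fold lower number from compound 1 to compound 2 (0.21 log units; within the scatter), lies within the scatter. Compound 3 `C[C@H](Nc1nc(N)nc(N)c1C#N)c1c(-c2ccccc2)c(=O)n2cc(F)ccc2c1-c1ccc(F)cc1` differs from compound 2 by 4-fluorophenyl in place of cyclopropyl on an aromatic carbon. Going by the values given here, no measured step covers this change; the one step known, from methyl to cyclopropyl, was small. The expected step is therefore modest, a 1.4-fold lower number from compound 2 to compound 3 (0.16 log units; within the scatter), leaning downward. Compound 3 is estimated at 900 nM, ranging from 300 nM to 2700 nM.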

Compound 3, maximal plasma concentration: 7500 nM
The estimate for compound 3 lay 8.3-fold (0.92 log units) below the measured number, outside the stated range (above it).
By their numbers in this assay, from the lowest: compounds 2 and 1 (each within the scatter of the next); then compound 3.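

At this position, on an aromatic carbon two atoms from the ring nitrogen, the substituent can move the number beyond the scatter: the change to 4-fluorophenyl gives a 5.8-fold higher number from compound 2 to compound 3 (0.76 log units; beyond the scatter) and, set against methyl, a 3.6-fold higher number from compound 1 to compound 3 (0.55 log units; beyond the scatter) while the earlier change from methyl to cyclopropyl stayed within it. Among the three groups, only the aromatic ring stands apart. No measured evidence accounts for this rise.

From the compounds shown here alone, whether the rise needs the fluorine, or whether plain phenyl or a piperidine here would give the same number, remains open.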